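A few compounds are considered here, and "the series" means these few. Any claim that something is new, unique, unknown or untested is made for them only; others in the source may bear on it.

Measured so far:
compound 1, `Nc1cc(N)c2nc(-c3ccccc3)c(Oc3ccc(F)cc3)nc2c1`: 41700 nM
compound 2, `COc1cc(CNc2nc3cc(N)cc(N)c3nc2-c2ccccc2)cc(OC)c1OC`: 13800 nM

Both were run in a functional assay on SK-OV-3 cells (Homo sapiens) for inhibition, read by sulforhodamine B assay, with a stated time of 48 h; on this read-out higher numbers stand for weaker inhibition of growth and lower numbers for stronger inhibition of growth. On those two numbers compound 1 stands highest; compound 2 sits lower by a margin beyond the usual scatter. Compound 3, `Nc1cc(N)c2nc(-c3ccccc3)c(NCc3ccc(F)cc3)nc2c1`, has not been measured. It differs from compound 1 by (4-fluorobenzyl)amino in place of 4-fluorophenoxy on an aromatic carbon. Among the compounds with values here, no step between measured compounds matches this change, so its size cannot be read off directly. A moderate step downward is expected, likely beyond the scatter but short of a large move, because compound 2 gives 13800 nM and shows that lower numbers than compound 1 are reachable on this core. For compound 3 the estimate in this assay is 20000 nM, range 7000 nM to 55000 nM. That estimate means an expected step of a 2.1-fold lower number from compound 1 to compound 3 (0.32 log units; beyond the scatter).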

Compound 3, concentration for total growth inhibition: 26300 nM
For compound 3 the middle estimate is 1.3-fold (0.12 log units) below the measured one; the range from low to high includes it.
By their numbers in this assay, from the lowest: compounds 2, 3 and 1 (each within the scatter of the next, the first and the last beyond it).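

Within the data shown here, at this aromatic carbon next to the ring nitrogen, (4-fluorobenzyl)amino in place of 4-fluorophenoxy gives in this assay the step of a 1.6-fold lower number from compound 1 to compound 3 (0.20 log units; within the scatter), the first step that can be read at this position. The entering group carries a hydrogen-bond donor that the leaving group lacks and has a nitrogen where the leaving group has an oxygen, yet on this read-out the two groups cannot be told apart. No measurement at hand bears on why the two groups read alike.

On these data alone, whether a primary amine, a morpholine or a longer chain between this carbon and the fluorophenyl ring would read differently remains open. Also open, as far as these compounds go, is whether a pyridine in place of the phenyl group on the shared core would shift the number.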